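This account rests on a few compounds, and the source may have more. Where it says the series, first, only, none or still open, it means among the compounds named here.

Measured compounds:
Compound 1, `C=C1CC[C@H]2C(C)(C)CCC[C@]2(C)[C@H]1CCC1=CC(=O)OC1`, 18800 nM
Compound 2, `C=C1CC[C@H]2C(C)(C)CCC[C@]2(C)[C@H]1C/C=C1\CC(OC)OC1=O`, 24600 nM
Compound 3, `C=C1CC[C@H]2C(C)(C)CCC[C@]2(C)[C@H]1CCC1=CC(O)OC1=O`, 25800 nM

In a functional assay on RAW264.7 cells (Mus musculus) for inhibition, with a stated time of 24 h (on this read-out lower numbers stand for stronger inhibition and higher numbers for weaker inhibition), compound 1 gives the lowest of the three numbers, but compound 2 and compound 3 both lie within the scatter of it, so no order among the three can be read from these figures. Going by the values given here, the only single-site step among them, a 1.4-fold higher number from compound 1 to compound 3 (0.14 log units; within the scatter), shows that exchanging one five-membered ring for another at the chain carbon two bonds from the ring leaves the read-out where it was.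

Compound 4, `C=C1CC[C@H]2C(C)(C)CCC[C@]2(C)[C@H]1C/C=C(/C=O)CCO`, is not yet measured. Compared with compound 1 it carries a group of 7 heavy atoms (5 carbon, 2 oxygen; no ring) in place of a group of 7 heavy atoms (5 carbon, 2 oxygen; one five-membered non-aromatic ring with 1 hetero atom), on a saturated chain carbon bound to a saturated ring carbon. Among the compounds with values here, no measured step bears directly on this change: the ring is lost altogether, which none of the steps among compound 1, compound 2 and compound 3 tests. With only the flat step from compound 1 to compound 3 as a guide, the author expects no movement beyond the scatter. Compound 4 is therefore estimated at 17000 nM, in the range 5500 nM to 50000 nM, an expected step of a 1.1-fold lower number from compound 1 to compound 4 (0.04 log units; within the scatter).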

Compound 4, half-maximal inhibitory concentration: > 50000 nM
Compound 4 gave a limit, no number; the forecaster's own chance of this, stated with the estimate: 10%; middle value at least 2.9-fold (0.46 log units) from the limit.
By their numbers in this assay, from the lowest: compounds 1, 2 and 3 (each within the scatter of the next). At a limit, above all of these: compound 4.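

Replacing the five-membered non-aromatic ring with 1 hetero atom by a group with no ring, on a saturated chain carbon bound to a saturated ring carbon, gives an at least 2.6-fold higher number from compound 1 to compound 4 (0.42 log units; beyond the scatter), a step beyond the scatter, whereas exchanging one such ring for another gave only a 1.4-fold higher number from compound 1 to compound 3 (0.14 log units; within the scatter). Among these compounds, then, the read-out in this assay tolerates a change of ring at this place but not the loss of the ring, even though the heavy-atom count stays the same. Compound 4 gives a limit and not a number, so this step has a lower bound but no known size: the limit of > 50000 nM in this assay, at which 1 of the 4 values shown sits.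

The compounds shown leave open whether a five-membered lactam would hold the read-out as the rings of compound 1 and compound 3 do. They also leave open how an open chain ending in a carboxylic acid or an amine would compare with compound 4.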